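Carboxy to Sulfamoyl on the Aryl Ring

This account rests on a few compounds, and the source may have more. Where it says the series, first, only, none or still open, it means among the compounds named here.

Measured so far in an assay (Rattus norvegicus) for inhibition of Fatty-acid amide hydrolase 1 (Homo sapiens); on this read-out higher numbers stand for weaker inhibition and lower numbers for stronger inhibition:
- compound 1, `Nc1ccccc1-c1cnc(C(=O)CCCCCCc2ccccc2)o1`, gives 750 nM
- compound 2, `COc1ccccc1-c1cnc(C(=O)CCCCCCc2ccccc2)o1`, gives 400 nM
- compound 3, `O=C(O)c1ccc(-c2cnc(C(=O)CCCCCCc3ccccc3)o2)cc1`, gives 60 nM

Compound 3 has the lowest number of the three, standing beyond the scatter from both others: a 13-fold lower number from compound 1 to compound 3 (1.10 log units; beyond the scatter) and a 6.7-fold lower number from compound 2 to compound 3 (0.82 log units; beyond the scatter). Compound 4, `NS(=O)(=O)c1ccc(-c2cnc(C(=O)CCCCCCc3ccccc3)o2)cc1`, differs from compound 3 by sulfamoyl in place of carboxy on an aromatic carbon. Among the compounds with values here, no measured step exchanges one group for another at this position, so the only guide is that the 4-carboxyphenyl of compound 3 outperforms the 2-aminophenyl and 2-methoxyphenyl partners in this assay. A sulfamoyl group keeps a donor and acceptors in the same place, so the number for compound 4 is expected to stay fairly close to compound 3, drifting modestly upward: a 2.5-fold higher number from compound 3 to compound 4 (0.40 log units; beyond the scatter). The estimate for compound 4 is 150 nM, with a range of 40 nM to 600 nM.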

Compound 4, inhibition constant: 10 nM
Estimate against measurement, compound 4: 15-fold (1.18 log units) above, outside the stated range (below it).
By their numbers in this assay, from the lowest: compound 4; then compound 3; then compounds 2 and 1 (each within the scatter of the next).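

In this assay, within the data shown here, sulfamoyl in place of carboxy on this aromatic carbon gives a 6.0-fold lower number from compound 3 to compound 4 (0.78 log units; beyond the scatter) and brings the lowest number so far. The carboxy group is therefore not needed for the low number of compound 3, and this position accepts the larger sulfamoyl group with a further gain. Nothing available explains why the number falls.

On these data alone, whether a simple carboxamide or a methylsulfonyl group at the same place would match sulfamoyl remains open. So does whether sulfamoyl would give a similar result elsewhere on the ring.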